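A few compounds are considered here, and "the series" means these few. Any claim that something is new, unique, unknown or untested is made for them only; others in the source may bear on it.

Measured so far in an ADME assay on Raji cells (Homo sapiens) for cytotoxicity, read by luminescence, with a stated time of 72 h; a lower number here means that less compound is needed, a higher number that more compound is needed for the effect:
compound 1 `CCOC(=O)c1c(-c2cccc(C)c2)[nH]c2cc(OC)ccc2c1=O`: > 21500 nM
compound 2 `CCOC(=O)c1c(-c2cccc(OCC(C)C)c2)[nH]c2cc(OC)ccc2c1=O`: > 21500 nM
compound 3 `CCOC(=O)c1c(-c2cccc(C(F)(F)F)c2)[nH]c2cc(OC)ccc2c1=O`: > 21500 nM

All three entries are limits of the assay, not numbers, as the limit of > 21500 nM in this assay, at which 3 of the 3 values shown sit, shows. In this assay compound 3 therefore has only a limit, > 21500 nM. It shares that position with compound 1 and compound 2, so it cannot be ranked against either.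

Putting fluoro in place of trifluoromethyl on an aromatic carbon of compound 3 gives compound 4 `CCOC(=O)c1c(-c2cccc(F)c2)[nH]c2cc(OC)ccc2c1=O`: fluoro in place of trifluoromethyl on an aromatic carbon. Among the compounds with values here, three measured steps bear on this change: a step that the two limits leave unreadable from compound 1 to compound 3, a step that the two limits leave unreadable from compound 2 to compound 3 and a step that the two limits leave unreadable from compound 1 to compound 2. None of them has a readable size, but the methyl, isobutoxy and trifluoromethyl compounds all sit at the same limit. No step beyond the usual scatter is therefore expected in this assay, and compound 4 will most likely report a limit as well. The expected change is a number no higher from compound 3 to compound 4 (the limit leaves the size open). For compound 4 the estimated value is 21500 nM, with an expected range of 9000 nM to 40000 nM.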

Compound 4, half-maximal effective concentration: > 21500 nM
Compound 4: a limit, no number; the forecaster's own chance of this, stated with the estimate: 85%; the middle value lies on the limit itself.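

In this assay compound 4 gives only a limit, > 21500 nM. The steps to it from compound 1, compound 2 and compound 3 therefore cannot be read: the limit of > 21500 nM in this assay, at which 4 of the 4 values shown sit. From the compounds shown here alone, how much of each compound the effect would need, and whether the four groups differ at all, stays open.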